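This account rests on a few compounds, and the source may have more. Where it says the series, first, only, none or still open, it means among the compounds named here.

Measured in a functional assay on U-87MG ATCC cells for inhibition, with U-87 MG (Homo sapiens) as the target, read by MTT assay, with a stated time of 48 h; a lower number here means a stronger inhibitor, a higher number a weaker inhibitor:

- Compound 1 `CS(=O)(=O)c1ccc(-c2nc3ccccn3c2Sc2ccccc2)cc1`: 77200 nM
- Compound 2 `Cc1ccc(-c2nc3ccccn3c2Sc2ccccc2)cc1`: > 100000 nM, a limit of the assay and not a number
- Compound 3 `Cc1ccc(-c2nc3ccc(C)cn3c2Sc2ccccc2)cc1`: 82100 nM

Compound 3 at 82100 nM and compound 1 at 77200 nM lie within the usual scatter of each other, so this assay does not separate them. Compound 3 is the starting point for the next change.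

Compound 4 `Cc1ccc2nc(-c3ccc(Cl)cc3)c(Sc3ccccc3)n2c1` keeps the shared core of compound 3 and changes one group: chloro in place of methyl on an aromatic carbon. In words, 4-methylphenyl becomes 4-chlorophenyl, with chloro in place of methyl on an aromatic carbon.

Within the data shown here, two measured steps bear on this. The closer one is an at least 1.2-fold higher number from compound 1 to compound 2 (0.11 log units; that floor lies within the scatter). It also exchanges a group on that same ring. The other is an at least 1.2-fold lower number from compound 2 to compound 3 (0.08 log units; that floor lies within the scatter), which adds a methyl elsewhere on the molecule. Both steps have compound 2 at one end, and the limit of > 100000 nM in this assay, at which 1 of the 3 values shown sits, means that each gives only a floor. Neither shows a change beyond the scatter, so no step beyond the scatter is expected here, in either direction. The estimated change is a 1.1-fold lower number from compound 3 to compound 4 (0.04 log units; within the scatter). For compound 4 the expected value is 75000 nM, with an estimated range from 38000 nM to 120000 nM.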

Compound 4, half-maximal inhibitory concentration: > 100000 nM
Compound 4: no number, only a limit; the forecaster's own chance of this, stated with the estimate: 25%; middle value at least 1.3-fold (0.12 log units) away from the limit.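

In this assay compound 4 gives > 100000 nM, which is a limit of the assay and not a number. Exchanging 4-methylphenyl for 4-chlorophenyl gives an at least 1.2-fold higher number from compound 3 to compound 4 (0.08 log units; that floor lies within the scatter), and this is the first step shown at this ring position on the core that carries the extra methyl, since the earlier exchange there, between compound 1 and compound 2, was on the core without it. Like the earlier steps, this one sets only a floor and shows no change beyond the scatter, so the true size of the step from methyl to chloro stays unknown, and only a floor can be given: the limit of > 100000 nM in this assay, at which 2 of the 4 values shown sit.

The compounds shown leave open whether any group at this ring position can move the number beyond the scatter, for instance an amine or a carboxylic acid in place of the chloro. They also leave open whether changes elsewhere, such as an amine on the phenyl ring attached through sulfur, would bring the values well clear of the limit, where steps could be read as real numbers.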